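Methoxycarbonyl to ethoxycarbonyl in a series at its limit

The source may report more compounds than this note shows. Statements on the series, on what has been measured and on what is new or still open speak of the compounds shown alone.

In a functional assay on the whole organism for antagonist activity, with Mus musculus as the target (on this read-out lower numbers stand for an effect already at smaller amounts and higher numbers for an effect only at larger amounts of compound), compound 1 (`CC(=O)N(C)CC#CCN1CCCC1`) gives > 10 mg/kg as a limit of the assay and not a number. Compound 2 (`COC(=O)N(C)CC#CCN1CCCC1`) gives > 10 mg/kg in this assay, again a limit and not a number. Compound 2 therefore has no numerical position in the series, and the evidence so far is the limit of > 10 mg/kg in this assay, at which 2 of the 2 values shown sit, and nothing more.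

Compound 3 (`CCOC(=O)N(C)CC#CCN1CCCC1`) differs from compound 2 by one change, methyl in place of hydrogen on a saturated chain carbon bound to an oxygen next to a carbonyl group in the count, which is methyl in place of hydrogen on a saturated chain carbon bound to an oxygen next to a carbonyl group, or methoxy to ethoxy.

Within the data shown here, the only measured step that bears on this change is a step that the two limits leave unreadable from compound 1 to compound 2 with methoxy in place of methyl on a carbonyl carbon, so it offers no size or direction to carry over. Among the measured compounds shown here, no step of readable size is expected in this assay, and compound 3 is expected to stop at the same limit. The estimated step that the limit leaves unreadable from compound 2 to compound 3 rests on this expectation alone. For compound 3 the estimate is 20 mg/kg with an expected range from 8 mg/kg to 50 mg/kg in the event that a number is reported.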

Compound 3, dose for half-maximal effect: > 100 mg/kg
Compound 3 gave a limit, no number (the forecaster's own chance of this, stated with the estimate: 80%); at least 5.0-fold (0.69 log units) between middle value and limit.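

In this assay compound 3 gives > 100 mg/kg, a limit and not a number. Among these compounds, with compound 1 and compound 2 also at limits, no step to compound 3 can be read. The compounds shown leave open whether methoxycarbonyl to ethoxycarbonyl changes the effect at all, and in which direction.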